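The source may hold more compounds than are shown below. What is called first, only, known or untested is meant among the compounds shown, and "the series" means these compounds.

Measured so far in a functional assay on MDA-MB-231 cells (Homo sapiens) for inhibition, read by MTT assay, with a stated time of 72 h; on this read-out higher numbers stand for weaker inhibition and lower numbers for stronger inhibition:
Compound 1 `COC(=O)c1ccc(-n2cc(CCCNC(=O)c3ccc(C)cc3)nn2)cc1`: > 100000 nM
Compound 2 `COC(=O)c1ccc(-n2cc(CCCNC(=S)c3ccc(C)cc3)nn2)cc1`: 82400 nM

The reading for compound 1, > 100000 nM, is a limit of the assay and not a number. Compound 1 therefore stands at the limit of > 100000 nM in this assay, at which 1 of the 2 values shown sits.

Compound 3 `COC(=O)c1ccc(-n2cc(CCCNC(=O)Nc3ccc(C)cc3)nn2)cc1` has not been measured. It carries (4-methylphenyl)amino in place of 4-methylphenyl on a carbonyl carbon.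

Within the data shown here, only one measured step bears on this change, and only loosely, since it alters the same carbonyl group but adds no amino group: an at least 1.2-fold lower number from compound 1 to compound 2 (0.08 log units; that floor lies within the scatter). Among the measured compounds shown here, with compound 2 at 82400 nM as the only true number, no change beyond the scatter is expected in this assay. The expected size of the change is small: an at least 1.1-fold lower number from compound 1 to compound 3 (0.04 log units; that floor lies within the scatter). For compound 3 the estimate is 90000 nM, with an expected range of 35000 nM to 180000 nM.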

Compound 3, half-maximal inhibitory concentration: 11600 nM
Estimate against measurement, compound 3: 7.8-fold (0.89 log units) above; measured number below the stated range.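

In this assay compound 1 gives > 100000 nM, which is a limit of the assay and not a number. Putting (4-methylphenyl)amino in place of 4-methylphenyl on the carbonyl carbon gives an at least 8.6-fold lower number from compound 1 to compound 3 (0.93 log units; beyond the scatter), so this position does respond to a change, whereas replacing the carbonyl oxygen with sulfur gave only an at least 1.2-fold lower number from compound 1 to compound 2 (0.08 log units; that floor lies within the scatter). The true size of the new step cannot be read, only its floor: the limit of > 100000 nM in this assay, at which 1 of the 3 values shown sits.

The compounds shown leave open whether the gain depends on the added nitrogen with its hydrogen-bond donor, or would also appear with an oxygen or a methylene in its place. They also leave open whether a sulfur in place of the carbonyl oxygen would add anything once the (4-methylphenyl)amino group is present.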